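A few compounds are considered here, and "the series" means these few. Any claim that something is new, unique, unknown or untested is made for them only; others in the source may bear on it.

Measured compounds:
Compound 1, `COCc1nc(Nc2ccc(C(F)(F)F)cc2)c2ccc(-c3ncccc3C(F)(F)F)cc2n1`, gives 1.5 nM in a functional assay for antagonist activity at transient receptor potential cation channel subfamily V member 1 (Homo sapiens); a lower number here means a stronger inhibitor, a higher number a weaker inhibitor.
Compound 2, `CCOCc1nc(Nc2ccc(C(F)(F)F)cc2)c2ccc(-c3ncccc3C(F)(F)F)cc2n1`, gives 0.9 nM in this assay.
Compound 3, `OCCc1nc(Nc2ccc(C(F)(F)F)cc2)c2ccc(-c3ncccc3C(F)(F)F)cc2n1`, gives 22 nM in this assay.

Compound 2 has the lowest number of the three in this assay. Its nearest neighbour is compound 1, with a 1.7-fold lower number from compound 1 to compound 2 (0.22 log units; within the scatter), so the two cannot be ranked against each other. Its furthest neighbour is compound 3, with a 24-fold higher number from compound 2 to compound 3 (1.39 log units; beyond the scatter).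

Compound 4, `CNCc1nc(Nc2ccc(C(F)(F)F)cc2)c2ccc(-c3ncccc3C(F)(F)F)cc2n1`, has not yet been measured. It differs from compound 2 in one place: methylamino in place of ethoxy on a saturated chain carbon bound to an aromatic carbon.

Among the compounds with values here, two measured steps bear on this. The step from compound 1 to compound 3, a 15-fold higher number from compound 1 to compound 3 (1.17 log units; beyond the scatter), and the step from compound 2 to compound 3, a 24-fold higher number from compound 2 to compound 3 (1.39 log units; beyond the scatter), both put a hydrogen-bond donor on the saturated chain carbon bound to an aromatic carbon, and both were large losses. The step of a 1.7-fold lower number from compound 1 to compound 2 (0.22 log units; within the scatter) shows that the size of the ether alone changes little. Within the data shown here, no measured step tests methylamino itself, so the account rests on the donor-bearing compound 3 alone.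

Compound 4 is therefore expected to give a higher number than compound 2, a step of about a 6.7-fold higher number from compound 2 to compound 4 (0.82 log units; beyond the scatter), likely smaller than the loss seen with compound 3 because a 24-fold higher number from compound 2 to compound 3 (1.39 log units; beyond the scatter) concerned a different group. The estimate for compound 4 in this assay is 6 nM, within a range of 1.5 nM to 30 nM.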

Compound 4, half-maximal inhibitory concentration: 26 nM
Compound 4: the middle estimate sits 4.3-fold (0.64 log units) below what was measured, and the stated range covers the measured number.
By their numbers in this assay, from the lowest: compounds 2 and 1 (each within the scatter of the next); then compounds 3 and 4 (each within the scatter of the next).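

In this assay, methylamino is a second group, after hydroxymethyl, that costs far more than the change between the two ethers, with a 29-fold higher number from compound 2 to compound 4 (1.46 log units; beyond the scatter) and a 17-fold higher number from compound 1 to compound 4 (1.24 log units; beyond the scatter), so the large loss at this place is not peculiar to compound 3. The two donor-bearing groups cannot be told apart, with a 1.2-fold higher number from compound 3 to compound 4 (0.07 log units; within the scatter), even though one brings a nitrogen to the saturated chain carbon bound to an aromatic carbon and the other does not. Among these four compounds, the two with an ether at this place give lower numbers than the two with a hydrogen-bond donor, no compound goes against this split, and nothing measured here accounts for it.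

The compounds shown leave open whether the loss follows the hydrogen-bond donor itself or something else about these groups; dimethylamino at this place, which keeps the nitrogen but has no amine hydrogen, would separate the two. How far the ether can grow also stays open, as the ethers shown stop at ethoxy and propoxy would extend that series.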